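The compounds below may be only part of what the source reports. "The series", "measured", "known", "first", "only" and "open" are said of these compounds alone.

Compound 1 `N#Cc1cnc(NCc2cnccc2C(F)(F)F)cc1N[C@H]1CC[C@@H](O)CC1` is the reference point of this account. In an assay on isolated protein for inhibition of protein kinase C theta type (Homo sapiens), read by TR-FRET, with a stated time of 2 h (on this read-out lower numbers stand for stronger inhibition and higher numbers for weaker inhibition), compound 1 gives 100 nM, which is the higher of the two numbers recorded so far. Its neighbour compound 2 `CC(C)(F)c1ncncc1CNc1cc(N[C@H]2CC[C@@H](O)CC2)c(C#N)cn1` belongs to a different series in which the pyridine bearing the trifluoromethyl group is replaced by a pyrimidine carrying a fluoro-isopropyl group, and in this assay compound 2 gives 32 nM, a lower number than that of compound 1 and a gap that goes beyond the usual scatter of the measurement. Among the compounds with values here, no single-point step between two measured compounds is available, so the effect of the change that leads to compound 3 `CC1(C)C[C@@H](Nc2cc(NCc3cnccc3C(F)(F)F)ncc2C#N)CC[C@H]1O` cannot be read from any measured pair. The change is 4-hydroxy-3,3-dimethylcyclohexyl in place of 4-hydroxycyclohexyl on a nitrogen on an aromatic ring, leaving the rest of compound 1 untouched. Without a comparable measured pair, the step of a 1.1-fold lower number from compound 1 to compound 3 (0.05 log units; within the scatter) is expected to stay within the scatter, with no direction favoured. Compound 3 is therefore estimated at 90 nM, in a range from 30 nM to 300 nM.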

Compound 3, half-maximal inhibitory concentration: 120 nM
Compound 3: the middle estimate sits 1.3-fold (0.12 log units) below what was measured; low and high end bracket the measured number.
By their numbers in this assay, from the lowest: compound 2; then compounds 1 and 3 (each within the scatter of the next).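

In this assay, within the data shown here, putting 4-hydroxy-3,3-dimethylcyclohexyl in place of 4-hydroxycyclohexyl on a nitrogen on an aromatic ring gives a 1.2-fold higher number from compound 1 to compound 3 (0.08 log units; within the scatter) and is the only step in this account that can be read from a measured pair. It shows that, with the rest of compound 1 untouched, this position takes the larger group without a number that can be told apart from that of compound 1, while the counts of hydrogen-bond donors, hydrogen-bond acceptors and defined stereocentres stay the same. Nothing measured here bears on why the two compounds read alike.

The compounds shown leave open whether the hydroxyl on this ring matters at all, since every group at this position still carries it, and an amine or a carboxylic acid in its place could separate from compound 1 on this read-out or could not. Among these compounds, they also leave open whether 4-hydroxy-3,3-dimethylcyclohexyl would read the same on the pyrimidine with its fluoro-isopropyl group found in compound 2, which is the only compound here whose number stands beyond the scatter of the others.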